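Swapping a Halogen on the Ring Attached to Nitrogen

A few compounds are considered here, and "the series" means these few. Any claim that something is new, unique, unknown or untested is made for them only; others in the source may bear on it.

Compound 2, `Oc1cc(C(F)(F)F)ccc1-c1nc(-c2ccccc2O)n(-c2ccccc2F)n1`, carries a 2-fluorophenyl on an aromatic nitrogen of the shared core. In a functional assay on PC-12 cells (Rattus norvegicus) for cytotoxicity, read by MTT assay, with stated times of 2 h and 24 h, tested at 5 uM (on this read-out higher numbers stand for a stronger effect at the one concentration tested and lower numbers for a weaker effect), compound 2 gives 86.6%, the lower of the two numbers recorded, while compound 1, `Oc1cc(C(F)(F)F)ccc1-c1nc(-c2ccccc2O)n(-c2ccc(C(F)(F)F)cc2)n1`, gives 90.5%; the two values sit within the usual scatter of each other, so neither can be called stronger.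

Compound 3, `Oc1cc(C(F)(F)F)ccc1-c1nc(-c2ccccc2O)n(-c2ccccc2Cl)n1`, differs from compound 2 in one place: chloro in place of fluoro on an aromatic carbon. For the measured compounds named here, the only measured step that touches the same ring on the aromatic nitrogen is a number 3.9 percentage points lower from compound 1 to compound 2 (within the scatter), which replaced a 4-(trifluoromethyl)phenyl by a 2-fluorophenyl and stayed within the scatter. That change was far larger than swapping one halogen for another, and it still left the read-out essentially unmoved. On this basis the expected step of a number 0.4 percentage points higher from compound 2 to compound 3 (within the scatter) is none beyond the scatter, in no particular direction. Compound 3 is therefore estimated to give 87% in this assay, with a range from 76% to 95%.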

Compound 3, a percentage reported as activity, at one concentration (the size of the read-out at that concentration, not a potency): 90.6%
Estimate against measurement, compound 3: 3.6 percentage points below; low and high end bracket the measured number.
By their numbers in this assay, from the lowest: compounds 2, 1 and 3 (each within the scatter of the next).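

In this assay, the swap of one halogen for another is now tested directly: chloro in place of fluoro on an aromatic carbon, ortho to a large group, gives a number 4 percentage points higher from compound 2 to compound 3 (within the scatter) and so does not separate the two compounds. The larger change, replacing the 4-(trifluoromethyl)phenyl on the aromatic nitrogen by a 2-chlorophenyl, gives a number 0.1 percentage points higher from compound 1 to compound 3 (within the scatter) and shows that a second ortho-halogenated ring on that nitrogen also cannot be told apart from the 4-(trifluoromethyl)phenyl compound, so all three compounds shown remain level within the scatter. Nothing available offers an explanation for how little these changes move the read-out.

As far as these compounds go, every ring on that nitrogen so far carries only fluorine-containing or chlorine-containing groups, so it remains open whether an amine or a carboxylic acid on this ring, or a longer chain in its place, would shift the number beyond the scatter. Each number also comes from a single concentration, so it gives only the size of the effect at that concentration, and these compounds could still show a stronger or weaker effect at other concentrations.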